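Sulfonyl Substituent and Stability in Human Liver Microsomes

The compounds below may be only part of what the source reports. "The series", "measured", "known", "first", "only" and "open" are said of these compounds alone.

Measured in an ADME assay on microsomes from liver (Homo sapiens) for metabolic stability, with a stated time of 10 min; a higher number here means that more of the compound is left, a lower number that less of the compound is left:
compound 1 `CC(C)S(=O)(=O)NC(=O)c1ccc(Nc2nc(NC3(c4ccc(Cl)cc4)CC3)nc(OCC(F)(F)F)n2)cc1` gives 100%
compound 2 `CC(C)C(=O)NCCS(=O)(=O)NC(=O)c1ccc(Nc2nc(NC3(c4ccc(Cl)cc4)CC3)nc(OCC(F)(F)F)n2)cc1` gives 86%
compound 3 `O=C(NS(=O)(=O)C1CC1)c1ccc(Nc2nc(NC3(c4ccc(Cl)cc4)CC3)nc(OCC(F)(F)F)n2)cc1` gives 100%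

Compound 3 stands level with compound 1, the two together highest of the three, as the step of no change at the digits printed from compound 1 to compound 3 (within the scatter) shows. Its furthest neighbour is compound 2: a number 14 percentage points higher from compound 2 to compound 3 (beyond the scatter).

Compound 4 `NCCS(=O)(=O)NC(=O)c1ccc(Nc2nc(NC3(c4ccc(Cl)cc4)CC3)nc(OCC(F)(F)F)n2)cc1` carries the change (2-aminoethyl in place of cyclopropyl on a sulfonyl sulfur). Among the compounds with values here, two measured steps bear on it. The step of no change at the digits printed from compound 1 to compound 3 (within the scatter) shows that swapping one small carbon group for another leaves this assay untouched. The step of a number 14 percentage points lower from compound 1 to compound 2 (beyond the scatter) shows that an ethyl chain bearing a nitrogen on the sulfonyl sulfur costs a modest amount. Compound 4 also places an ethyl chain with a nitrogen there, so a modest drop is expected: a number 15 percentage points lower from compound 3 to compound 4 (beyond the scatter). Compound 4 is therefore estimated at 85%, between 65% and 100%.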

Compound 4, percent of the compound remaining: 100%
Beside the measured number, compound 4's estimate is 15 percentage points below it, and the stated range covers the measured number.
By their numbers in this assay, from the lowest: compound 2; then compounds 1, 3 and 4 (each within the scatter of the next).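

In this assay the change to 2-aminoethyl on the sulfonyl sulfur gives no change at the digits printed from compound 3 to compound 4 (within the scatter) and, against isopropyl, no change at the digits printed from compound 1 to compound 4 (within the scatter), so an ethyl chain bearing a nitrogen does not by itself lower the number at this position. The lower number of compound 2 therefore goes with the isopropylcarbonyl on the amine nitrogen, as replacing it with hydrogen gives a number 14 percentage points higher from compound 2 to compound 4 (beyond the scatter). Nothing available here explains these results.

The compounds shown leave open whether a longer amine chain or a carboxylic acid on the sulfonyl sulfur would behave like 2-aminoethyl. They also leave open whether an acetyl group on the amine nitrogen would behave like isopropylcarbonyl.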